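This account rests on a few compounds, and the source may have more. Where it says the series, first, only, none or still open, it means among the compounds named here.

Measured compounds:
compound 1, `O=C1NC(=O)/C(=C/c2ccc(OCCSc3nnc(-c4ccccc4)[nH]3)cc2)S1`: 26.4%
compound 2, `O=C1NC(=O)/C(=C/c2ccc(OCCSc3nnc(-c4ccccc4)o3)cc2)S1`: 24.1%

Both numbers come from a functional assay on the whole organism (strain Wistar) with Rattus norvegicus as the target, with a stated time of 15 days, at a dose of 30 mg/kg by the oral route; a higher number here means a stronger effect of the compound at the dose given, a lower number a weaker effect. Compound 1 gives 26.4% in this assay, and compound 2 gives 24.1%. For the measured compounds named here, compound 2 is the only other measured compound, and its number lies within the usual scatter of the number for compound 1, so the two cannot be told apart on what has been measured; neither can be called stronger or weaker.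

The next compound, compound 3, `O=C1NC(=O)/C(=C/c2ccc(OCCSc3nnc(-c4ccncc4)o3)cc2)S1`, has not yet been measured in this assay. It differs from compound 2 in one place: pyridin-4-yl in place of phenyl on an aromatic carbon.

Going by the values given here, nothing measured so far shows what such an exchange does to the read-out in this assay, since the two measured compounds differ elsewhere. With no guide from a measured pair, the step in this assay from a number 0.1 percentage points lower from compound 2 to compound 3 (within the scatter) is expected to stay within the scatter, in no clear direction. Compound 3 is therefore expected to give about 24% in this assay, with a likely range from 12% to 36%.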

Compound 3, a percentage reported as activity, at one dose (the size of the read-out at that dose, not a potency): 58.5%
Compound 3: middle estimate off by 34.5 percentage points, on the low side, outside the stated range (above it).
By their numbers in this assay, from the lowest: compounds 2 and 1 (each within the scatter of the next); then compound 3.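

In this assay, putting pyridin-4-yl in place of phenyl on this aromatic carbon of the five-membered ring with 2 nitrogen and 1 oxygen brings a number 34.4 percentage points higher from compound 2 to compound 3 (beyond the scatter), so the group held at this position can strongly change the read-out at the dose given. The exchange is a small one on paper: both groups have 6 heavy atoms and form one six-membered aromatic ring, and the counted differences are that 1 ring carbon becomes nitrogen and the entering group has 1 hydrogen-bond acceptor where phenyl has 0. No measurement shown here gives any explanation for this step.

The compounds shown leave open whether the place of the ring nitrogen matters, since a pyridin-3-yl or pyridin-2-yl group at the same position could give a similar number or a quite different one. Also open, on these data alone, is whether a phenyl ring carrying an amine would serve as well, and whether the same exchange on the core of compound 1, with its ring bearing the ring hydrogen, would bring a step of similar size.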